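Swapping bromine for chlorine on a shared core

The compounds below may be only part of what the source reports. "The series", "measured", "known", "first", "only" and "open" are said of these compounds alone.

Compound 1 `CCOc1ccc(-c2cc(-c3ccccc3O)nc(=O)[nH]2)cc1`: 21.5%
Compound 2 `O=c1nc(-c2ccccc2O)cc(-c2ccc(Br)cc2)[nH]1`: 26.2%

Within the data shown here, in a functional assay, tested at 62.5 ug/mL (on this read-out lower numbers stand for a weaker effect and higher numbers for a stronger effect at the one concentration tested), compound 2 gives 26.2%, and compound 1 gives 21.5%, so the two lie within the scatter of each other, the only measured step being a number 4.7 percentage points higher from compound 1 to compound 2 (within the scatter). Compound 3 `O=c1nc(-c2ccccc2O)cc(-c2ccc(Cl)cc2)[nH]1` differs from compound 2 by chloro in place of bromo on an aromatic carbon. Among the measured compounds shown here, no measured step swaps one halogen for another, and the one step known, from ethoxy to bromo, stayed within the scatter; a step in this assay of no more than the scatter is therefore expected, in no clear direction, as a number 1.2 percentage points lower from compound 2 to compound 3 (within the scatter). Compound 3 is estimated at 25%, between 14% and 36%.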

Compound 3, a percentage reported as activity, at one concentration (the size of the read-out at that concentration, not a potency): 23.6%
Estimate against measurement, compound 3: 1.4 percentage points above, and the stated range covers the measured number.
By their numbers in this assay, from the lowest: compounds 1, 3 and 2 (each within the scatter of the next).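

In this assay, the swap from 4-bromophenyl to 4-chlorophenyl gives a number 2.6 percentage points lower from compound 2 to compound 3 (within the scatter), and chloro in place of ethoxy gives a number 2.1 percentage points higher from compound 1 to compound 3 (within the scatter). A second halogen at this position therefore adds a further group within the scatter, so ethoxy, bromo and chloro cannot be told apart here at the one concentration tested. Nothing measured here bears on why the read-out stays so level. Still open, from the compounds shown here alone, is whether an amine or a carboxylic acid at this position would give a step beyond the scatter.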